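The source may report more compounds than this note shows. Statements on the series, on what has been measured and on what is new or still open speak of the compounds shown alone.

Compound 1 `CCc1nc(N)c2nn(-c3ccccc3)cc2n1`, compound 2 `Nc1nc(CCc2ccccc2)nc2cn(-c3ccccc3)nc12` and compound 3 `COc1ccc(CCCc2nc(N)c3nn(-c4ccccc4)cc3n2)cc1` share one core and differ only in what hangs from a chain carbon on it. In an assay on CHO cells for displacement of a labelled ligand from adenosine receptor A3 (Homo sapiens), read by scintillation counting, tested at 1 uM (a lower number here means less inhibition, a higher number more inhibition at the concentration tested (going by the name of the read-out)), compound 1 gives 38%. In this assay compound 2 gives 17%, and compound 3 gives 1%. The change from compound 1 to compound 2 is phenyl in place of hydrogen on a saturated chain carbon, two bonds along the chain from an aromatic carbon, and it made a step of a number 21 percentage points lower from compound 1 to compound 2 (beyond the scatter). The larger replacement from compound 1 to compound 3 made a step of a number 37 percentage points lower from compound 1 to compound 3 (beyond the scatter), and the step of a number 16 percentage points lower from compound 2 to compound 3 (beyond the scatter) leaves compound 3 with the lowest of the three numbers.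

Compound 4 `Nc1nc(CCCc2ccc(OCc3ccccc3)cc2)nc2cn(-c3ccccc3)nc12` has not yet been measured. It differs from compound 3 by phenyl in place of hydrogen on a saturated chain carbon bound to an oxygen on an aromatic ring. Within the data shown here, this is the same kind of change as the one from compound 1 to compound 2, phenyl in place of hydrogen on a saturated chain carbon, but the place is not the same: in compound 2 that carbon is two bonds along the chain from an aromatic carbon, whereas in compound 4 it is bound to an oxygen on an aromatic ring. The two cores themselves differ by 4-methoxybenzyl in place of hydrogen on a saturated chain carbon, two bonds along the chain from an aromatic carbon.

Since compound 3 already stands at 1%, there is little room for a further drop of the size seen from compound 1 to compound 2, so the step from compound 3 to compound 4 is expected to be about a number 3 percentage points higher from compound 3 to compound 4 (within the scatter). Compound 4 is therefore expected to give about 4% in this assay, likely between -8% and 18%.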

Compound 4, a percentage reported as inhibition, at one concentration (the size of the read-out at that concentration, not a potency): 2%
The estimate for compound 4 lay 2 percentage points above the measured number; measured number inside the range.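

In this assay, phenyl in place of hydrogen on a saturated chain carbon bound to an oxygen on an aromatic ring, the change from methoxy to benzyloxy, gave a step of a number 1 percentage points higher from compound 3 to compound 4 (within the scatter), so these two compounds cannot be told apart. Set beside the earlier step, the same kind of change did not carry over from one core to the other in this series: the same change on two cores in this assay, a number 21 percentage points lower (beyond the scatter) from compound 1 to compound 2 and a number 1 percentage points higher (within the scatter) from compound 3 to compound 4, 22 percentage points apart, beyond the scatter of two such steps This does not show what sets the two steps apart, since the phenyl enters at a different place in each case and, with only one pair on each core, the gap cannot be assigned to the place, to the core, or to compound 3 already standing at 1%, where little room remains for any further drop.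

The compounds shown leave open how an amine or a carboxylic acid at the end of the chain, or a longer chain, would read in this assay. Since the read-out comes from a single concentration and gives no potency, they also leave open whether compound 3 and compound 4 would separate at a higher concentration.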